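Replacing Pyrrolidin-1-yl with Methylamino on the Carbonyl Carbon

The source may hold more compounds than are shown below. What is called first, only, known or untested is meant among the compounds shown, and "the series" means these compounds.

Of the compounds shown here, three sharing one core have been measured in a functional assay on HCT-116 cells (Homo sapiens) for cytotoxicity, read by MTT assay, with a stated time of 72 h; a higher number here means a weaker inhibitor, a lower number a stronger inhibitor. Compound 1 `COc1ncc(-c2ccc3nc(NC(=O)NCC(=O)N4CCCCC4)nn3c2)cc1NS(=O)(=O)c1ccc(F)cc1` gives 130 nM, compound 3 `COc1ncc(-c2ccc3nc(NC(=O)NCCN(C)C)nn3c2)cc1NS(=O)(=O)c1ccc(F)cc1` gives 220 nM, and compound 2 `COc1ncc(-c2ccc3nc(NC(=O)N4CCCC4)nn3c2)cc1NS(=O)(=O)c1ccc(F)cc1` gives 1290 nM. Compound 2 therefore stands highest of the three, its steps to both others lying beyond the scatter: a 9.9-fold higher number from compound 1 to compound 2 (1.00 log units; beyond the scatter) and a 5.9-fold lower number from compound 2 to compound 3 (0.77 log units; beyond the scatter). Between compound 1 and compound 3 the difference is small: a 1.7-fold higher number from compound 1 to compound 3 (0.23 log units; within the scatter).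

Compound 4 `CNC(=O)Nc1nc2ccc(-c3cnc(OC)c(NS(=O)(=O)c4ccc(F)cc4)c3)cn2n1` differs from compound 2 by one change: methylamino in place of pyrrolidin-1-yl on a carbonyl carbon. Both measured steps that start or end at compound 2 bear on this: in each, a pyrrolidin-1-yl on that carbonyl carbon goes with the higher number, while an amino-type group bearing a hydrogen-bond donor goes with a clearly lower one, by a 9.9-fold higher number from compound 1 to compound 2 (1.00 log units; beyond the scatter) and a 5.9-fold lower number from compound 2 to compound 3 (0.77 log units; beyond the scatter). Methylamino likewise brings a hydrogen-bond donor, so a lower number is expected in this assay, though methylamino is smaller than the groups of compound 1 and compound 3, so the expected step is more cautious: a 3.7-fold lower number from compound 2 to compound 4 (0.57 log units; beyond the scatter). Compound 4 is therefore estimated at 350 nM, within a range of 120 nM to 1000 nM.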

Compound 4, half-maximal inhibitory concentration: 180 nM
Compound 4: the middle estimate sits 1.9-fold (0.29 log units) above what was measured; the measured number falls inside the stated range.
By their numbers in this assay, from the lowest: compounds 1, 4 and 3 (each within the scatter of the next); then compound 2.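

The earlier compounds shown here left open whether the lower number needed the long chains of compound 1 and compound 3, and in this assay the step of a 7.2-fold lower number from compound 2 to compound 4 (0.86 log units; beyond the scatter) shows that methylamino alone on the carbonyl carbon is enough. The chain ends add nothing that can be read here: the steps are a 1.2-fold lower number from compound 3 to compound 4 (0.09 log units; within the scatter) and a 1.4-fold higher number from compound 1 to compound 4 (0.14 log units; within the scatter). No measurement shown accounts for the gap between pyrrolidin-1-yl and methylamino.

This change removes the ring, shrinks the group and adds a hydrogen-bond donor all at once, so the compounds shown cannot separate these three differences. Dimethylamino on the same carbonyl carbon, which has no ring and no hydrogen on its nitrogen, would help to pull them apart.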